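Replacing the 3,5-difluorophenyl group of compound 2

The source may hold more compounds than are shown below. What is called first, only, known or untested is meant among the compounds shown, and "the series" means these compounds.

Among the measured compounds shown here, in a functional assay on RT-112 cells (Homo sapiens) for antiproliferative activity, read by MTT assay, with a stated time of 72 h (on this read-out lower numbers stand for stronger inhibition of growth and higher numbers for weaker inhibition of growth), compound 1 `COc1cc(Nc2ncnc3c(NC(=O)Nc4ccccc4Cl)cccc23)cc(OC)c1` gives 356 nM and compound 2 `COc1cc(Nc2ncnc3c(NC(=O)Nc4cc(F)cc(F)c4)cccc23)cc(OC)c1` gives 2630 nM as the higher of the two numbers so far. Compound 3 `COc1cc(Nc2ncnc3c(NC(=O)Nc4ccc(Cl)c(C(F)(F)F)c4)cccc23)cc(OC)c1` shares the core of compound 2 but carries 4-chloro-3-(trifluoromethyl)phenyl in place of 3,5-difluorophenyl on an amide-type nitrogen. For the measured compounds named here, only one measured step bears on this place: a 7.4-fold higher number from compound 1 to compound 2 (0.87 log units; beyond the scatter) is modest but beyond the scatter, and it runs from 2-chlorophenyl to 3,5-difluorophenyl. Going by the values given here, no measured compound carries the entering group, so this step guides the direction only loosely. With compound 2 at the upper end and compound 1 as the sole lower reference, a modest move toward a lower number is expected. The expected change is a 2.9-fold lower number from compound 2 to compound 3 (0.47 log units; beyond the scatter) and it remains uncertain. For compound 3 the estimated value is 900 nM with 250 nM to 3000 nM as its expected range.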

Compound 3, concentration for 50% growth inhibition: > 20000 nM
Compound 3 ended at the assay's limit (the forecaster's own chance of this, stated with the estimate: 3%); middle value at least 22-fold (1.34 log units) from the limit.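

In this assay, compound 3 gives a limit and not a number: the limit of > 20000 nM in this assay, at which 1 of the 3 values shown sits. The change at this amide-type nitrogen therefore reads as an at least 7.6-fold higher number from compound 2 to compound 3 (0.88 log units; beyond the scatter), and against the 2-chlorophenyl group as an at least 56-fold higher number from compound 1 to compound 3 (1.74 log units; beyond the scatter). With the shared core unchanged, swapping the phenyl group at this place can thus do more than the modest shift seen earlier: 4-chloro-3-(trifluoromethyl)phenyl carries the read-out past what this assay reports, whereas compound 1 and compound 2 both gave measurable values.

From the compounds shown here alone, whether a phenyl group bearing chlorine alone or trifluoromethyl alone would behave in the same way remains open. Also open, going by these compounds, is how a phenyl group bearing a methoxy group or an amine at this nitrogen would compare with the 2-chlorophenyl group of compound 1.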